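Trimming the Amide Substituent of a Bis-sulfonamide Series

The source may report more compounds than this note shows. Statements on the series, on what has been measured and on what is new or still open speak of the compounds shown alone.

Compound 1 `CCN(CC)S(=O)(=O)c1ccc(S(=O)(=O)N2CCC[C@@H](C(=O)N[C@@H]3CCN(C(=O)OC(C)(C)C)C3)C2)cc1` gives 200 nM in a functional assay on MIA PaCa-2 cells (Homo sapiens) for inhibition, read by MTT assay, with a stated time of 7 days; a higher number here means a weaker inhibitor, a lower number a stronger inhibitor.
Compound 2 `CCOC(=O)[C@@H]1CCCN(S(=O)(=O)c2ccc(S(=O)(=O)N(CC)CC)nc2)C1` gives 5600 nM in this assay.
Compound 3 `CCOC(=O)N1CCC[C@H](S(=O)(=O)c2ccc(S(=O)(=O)N(CC)CC)cc2)C1` reaches only a limit of the assay, recorded as > 30000 nM in this assay.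

Compound 1 holds the lowest of the two numbers shown; compound 2 stands well away from it, a gap beyond the usual scatter. Compound 3 sits at the limit of > 30000 nM in this assay, at which 1 of the 3 values shown sits, and offers no number for comparison.

Compound 4 `CCN(CC)S(=O)(=O)c1ccc(S(=O)(=O)N2CCC[C@@H](C(=O)NC3COC3)C2)cc1` differs from compound 1 in one place: oxetan-3-yl in place of 1-(tert-butoxycarbonyl)pyrrolidin-3-yl on an amide-type nitrogen. Among the compounds with values here, no step between measured compounds isolates this change, so the expectation rests on the scale of what leaves and what enters. A step toward a higher number in this assay, beyond the scatter, is expected. The expected step is a 7.5-fold higher number from compound 1 to compound 4 (0.88 log units; beyond the scatter). Compound 4 is estimated at 1500 nM, between 400 nM and 6000 nM.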

Compound 4, half-maximal inhibitory concentration: 2300 nM
Estimate against measurement, compound 4: 1.5-fold (0.19 log units) below; measured number inside the range.
By their numbers in this assay, from the lowest: compound 1; then compound 4; then compound 2. At a limit, above all of these: compound 3.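

Placing oxetan-3-yl instead of 1-(tert-butoxycarbonyl)pyrrolidin-3-yl on the amide-type nitrogen gives a 12-fold higher number from compound 1 to compound 4 (1.06 log units; beyond the scatter) in this assay, a large step. Within the data shown here, this pair shows that the group at this one place can, on its own, shift the number this far, which the earlier compounds, differing in several places, could not show. Nothing shown here accounts for the step.

Which part of the departing group matters remains open. A bare pyrrolidin-3-yl ring or a simple tert-butyl group on this nitrogen would help divide the step between its parts.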